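Thiophene Replaces Dimethylaminophenyl on the Enone Chain

The source may hold more compounds than are shown below. What is called first, only, known or untested is meant among the compounds shown, and "the series" means these compounds.

Measured compounds in a functional assay on DU-145 cells (Homo sapiens) for inhibition, read by trypan blue exclusion, with a stated time of 96 h; a higher number here means a weaker inhibitor of growth, a lower number a stronger inhibitor of growth:
compound 1 `Cc1ccc(S(=O)(=O)/C(=C/c2sccc2C)C(=O)c2ccc(Br)cc2)cc1`: 25000 nM
compound 2 `COc1ccccc1/C=C(\C(=O)c1ccc(Br)cc1)S(=O)(=O)c1ccc(C)cc1`: 1000 nM
compound 3 `Cc1ccc(S(=O)(=O)/C(=C/c2ccc(N(C)C)cc2)C(=O)c2ccc(Br)cc2)cc1`: 50000 nM

Compound 3 gives the highest number of the three. Its nearest neighbour is compound 1, at a 2.0-fold higher number from compound 1 to compound 3 (0.30 log units; within the scatter), so these two cannot be told apart; compound 2 stands far away, at a 50-fold higher number from compound 2 to compound 3 (1.70 log units; beyond the scatter).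

Compound 4 `Cc1ccc(S(=O)(=O)/C(=C/c2ccc(C)s2)C(=O)c2ccc(Br)cc2)cc1` is not yet measured. It differs from compound 3 in one place: 5-methylthiophen-2-yl in place of 4-(dimethylamino)phenyl on a double-bonded chain carbon bound to a double-bonded chain carbon.

Within the data shown here, two measured steps bear on this change. The step of a 2.0-fold higher number from compound 1 to compound 3 (0.30 log units; within the scatter) compares a methylthiophenyl group with the dimethylaminophenyl group and stays within the scatter, so the reverse move toward a methylthiophenyl group is expected to give little change or a modest lowering of the number. The step of a 50-fold higher number from compound 2 to compound 3 (1.70 log units; beyond the scatter) shows that a change at this position can be large, but it involved a methoxyphenyl group, which compound 4 does not carry.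

Compound 4 is therefore estimated at 30000 nM, within a range of 10000 nM to 90000 nM. This estimate means a step of a 1.7-fold lower number from compound 3 to compound 4 (0.22 log units; within the scatter), expected to fall within or just beyond the scatter, with the number coming out somewhat lower than for compound 3.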

Compound 4, concentration for 50% growth inhibition: 25000 nM
Beside the measured number, compound 4's estimate is 1.2-fold (0.08 log units) above it; the measured number falls inside the stated range.
By their numbers in this assay, from the lowest: compound 2; then compounds 1, 4 and 3 (each within the scatter of the next).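

In this assay, the new compound shows that the site of the methyl group on the thiophene makes no readable difference at this place on the double-bonded chain carbon: 5-methylthiophen-2-yl in place of 3-methylthiophen-2-yl gives no change at the digits printed from compound 1 to compound 4 (within the scatter). The dimethylaminophenyl group and the new thiophene cannot be told apart either, with a 2.0-fold lower number from compound 3 to compound 4 (0.30 log units; within the scatter), whereas a 25-fold higher number from compound 2 to compound 4 (1.40 log units; beyond the scatter) is a large step, so among these four compounds only the 2-methoxyphenyl group of compound 2 stands apart from the rest.

How an unsubstituted phenyl, a 4-methoxyphenyl or a 2-ethoxyphenyl group would read here stays open, so the compounds shown cannot say whether the separation of compound 2 depends on the methoxy group, on where it sits, or on the six-membered ring that carries it. A methoxy group on a thiophene would also test whether the ring and the substituent can be judged apart, and the shared core stays the same throughout, so these results speak only for this one place. No measurement given here explains why any of these groups reads as it does.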